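The compounds below may be only part of what the source reports. "The series", "measured", "known", "first", "only" and "open" are said of these compounds alone.

Compound 1, with structure `CCCCC#Cc1nc(NCc2cccc(Cl)c2)c2ncn([C@H]3[C@H](O)[C@H](O)[C@@H]4C[C@@H]43)c2n1`, gives 10.7 nM in an assay on RBL-2H3 cells for displacement of a labelled ligand from adenosine receptor A3 (Rattus norvegicus), with a stated time of 60 min (on this read-out higher numbers stand for weaker inhibition and lower numbers for stronger inhibition), the lowest of the three numbers measured here. Compound 2, `CCCCC#Cc1nc(NCc2cccc(I)c2)c2ncn([C@H]3[C@H](O)[C@H](O)[C@@H]4C[C@@H]43)c2n1`, gives 26 nM, and compound 3, `CCCCC#Cc1nc(NCC)c2ncn([C@H]3[C@H](O)[C@H](O)[C@@H]4C[C@@H]43)c2n1`, gives 176 nM. Replacing the halogen is a small move: from compound 1 to compound 2 the number rises a 2.4-fold higher number from compound 1 to compound 2 (0.39 log units; beyond the scatter). Cutting away the aryl group matters far more: from compound 1 to compound 3 the change is a 16-fold higher number from compound 1 to compound 3 (1.22 log units; beyond the scatter), and from compound 2 to compound 3 it is a 6.8-fold higher number from compound 2 to compound 3 (0.83 log units; beyond the scatter).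

Compound 4, `CCCCC#Cc1nc(NC)c2ncn([C@H]3[C@H](O)[C@H](O)[C@@H]4C[C@@H]43)c2n1`, goes one step beyond compound 3 in the same direction: the difference from compound 1 is hydrogen in place of 3-chlorophenyl on a saturated chain carbon bound to a nitrogen on an aromatic ring, so the (3-chlorobenzyl)amino becomes a methylamino. The steps to compound 3 bear directly on this change and were large. A weakening at least as large is therefore expected, namely a 26-fold higher number from compound 1 to compound 4 (1.42 log units; beyond the scatter). Compound 4 is estimated to give 280 nM in this assay, with a range from 80 nM to 1000 nM.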

Compound 4, inhibition constant: 231 nM
Compound 4: the middle estimate sits 1.2-fold (0.08 log units) above what was measured; low and high end bracket the measured number.
By their numbers in this assay, from the lowest: compound 1; then compound 2; then compounds 3 and 4 (each within the scatter of the next).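

Among the small groups at this place, the step is a 1.3-fold higher number from compound 3 to compound 4 (0.12 log units; within the scatter), so removing that methyl leaves compound 3 and compound 4 indistinguishable on this read-out. The benzyl compounds stay clearly apart from compound 4, with a 22-fold higher number from compound 1 to compound 4 (1.33 log units; beyond the scatter) and an 8.9-fold higher number from compound 2 to compound 4 (0.95 log units; beyond the scatter), so among these compounds the loss of the substituted phenyl ring carries the change, while the length of the remaining small chain makes no measurable difference. No measured evidence is at hand to explain this behaviour.

On these data alone, it remains open whether an unsubstituted benzyl, a longer chain such as butyl, or a cyclopentyl group at this place would return the number towards that of compound 1. A free amino group, with no carbon chain on the nitrogen, is equally untested in the compounds shown here.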